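Dithiazolyl chromones: methyl to fluoro on the benzo ring

The compounds below may be only part of what the source reports. "The series", "measured", "known", "first", "only" and "open" are said of these compounds alone.

Measured compounds:
- compound 1, `Cc1ccc2occ(C3N=C(c4ccccc4)SS3)c(=O)c2c1`, 93700 nM
- compound 2, `O=c1c(C(=S)Nc2ccccc2)coc2cc(Cl)ccc12`, > 100000 nM
- compound 3, `O=c1c(C2N=C(c3ccccc3)SS2)coc2cc(Cl)c(Cl)cc12`, 65200 nM

In a functional assay on OVCAR-3 cells (Homo sapiens) for inhibition, read by sulforhodamine B assay, with a stated time of 48 h (on this read-out higher numbers stand for weaker inhibition and lower numbers for stronger inhibition), compound 1 gives 93700 nM. Compound 3 gives 65200 nM in this assay, and the gap to compound 1 lies within the scatter, so the two are not separable on these numbers. Compound 2 is the thioanilide and reaches only the limit of this assay, > 100000 nM; one of the three values shown sits at that limit (the limit of > 100000 nM in this assay, at which 1 of the 3 values shown sits). Among the measured compounds shown here, no two measured compounds differ in a single place, so no measured step is available.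

Compound 4, `O=c1c(C2N=C(c3ccccc3)SS2)coc2ccc(F)cc12`, is not yet measured. It differs from compound 1 by fluoro in place of methyl on an aromatic carbon. For the measured compounds named here, with no measured step to lean on, no change beyond the scatter is expected from this swap. Compound 4 is estimated at 95000 nM, in the range 45000 nM to 200000 nM, which means an expected step of a 1.0-fold higher number from compound 1 to compound 4 (0.01 log units; within the scatter).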

Compound 4, half-maximal inhibitory concentration: > 100000 nM
Compound 4: no number, only a limit; the forecaster's own chance of this, stated with the estimate: 40%; middle value at least 1.0-fold (0.02 log units) away from the limit.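

Compound 4 sits at > 100000 nM in this assay, which is a limit of the assay and not a number. Among the compounds shown here, this is the first single-place change, and fluoro in place of methyl on an aromatic carbon gives an at least 1.0-fold higher number from compound 1 to compound 4 (0.02 log units; that floor lies within the scatter), so it shows no gain in inhibition at this position, while the true size of the step stays unread. The top of the read-out now holds more of the series: the limit of > 100000 nM in this assay, at which 2 of the 4 values shown sit.

As far as these compounds go, how far compound 4 lies past the limit remains open, so this position cannot yet be ranked for methyl against fluoro. Also open, from the compounds shown here alone, is whether an amine or a carboxylic acid on this aromatic carbon, in place of methyl, would give a number clearly lower than that of compound 1.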